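Swapping an aryl ether for a benzyl ether on two cores

The source may hold more compounds than are shown below. What is called first, only, known or untested is meant among the compounds shown, and "the series" means these compounds.

Compound 1 `O=S(=O)(NCCNC(=S)Nc1cc(C(F)(F)F)cc(C(F)(F)F)c1)c1ccc(-c2ccccc2OCc2cccc(O)c2)s1` and compound 2 `O=[N+]([O-])c1ccc(Oc2ccccc2-c2ccc(S(=O)(=O)NCCNC(=S)Nc3cc(C(F)(F)F)cc(C(F)(F)F)c3)s2)cc1` share one core, while compound 3 `COc1ccc(NC(=O)NCCNS(=O)(=O)c2ccc(-c3ccccc3Oc3ccc([N+](=O)[O-])cc3)s2)cc1` and compound 4 `COc1ccc(NC(=O)NCCNS(=O)(=O)c2ccc(-c3ccccc3OCc3cccc(O)c3)s2)cc1` share another; the difference between the two cores is not broken down here. In a functional assay on RS4-11 cells (Homo sapiens) for inhibition, read by CCK-8 assay, with a stated time of 48 h (on this read-out lower numbers stand for stronger inhibition and higher numbers for weaker inhibition), compound 2 gives 6300 nM and compound 1 gives 12000 nM, so the change 3-hydroxybenzyl in place of 4-nitrophenyl on an oxygen on an aromatic ring produced a 1.9-fold higher number from compound 2 to compound 1 (0.28 log units; within the scatter). For compound 3 this assay reports only a limit, > 50000 nM, (the limit of > 50000 nM in this assay, at which 1 of the 3 values shown sits). Compound 4 carries the same change on its core, (3-hydroxybenzyl in place of 4-nitrophenyl on an oxygen on an aromatic ring). Since the earlier step stayed within the scatter, compound 4 is expected to remain near the limit of compound 3, the estimated step being a number no higher from compound 3 to compound 4 (the limit leaves the size open). Compound 4 is therefore estimated at 50000 nM, between 20000 nM and 150000 nM.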

Compound 4, half-maximal inhibitory concentration: 9400 nM
Beside the measured number, compound 4's estimate is 5.3-fold (0.73 log units) above it, and the stated range ends above it.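

In this assay, 3-hydroxybenzyl in place of 4-nitrophenyl on the oxygen gave an at least 5.3-fold lower number from compound 3 to compound 4 (0.72 log units; beyond the scatter). The change therefore did not carry over unaltered from one core to the other: the same change on two cores in this assay, a 1.9-fold higher number (0.28 log units; within the scatter) from compound 2 to compound 1 and an at least 5.3-fold lower number (0.72 log units; beyond the scatter) from compound 3 to compound 4, at least 10-fold (1.00 log units) apart, beyond the scatter of two such steps Compound 3 has only a limit, > 50000 nM, so the true size of this step is not shown, and neither is which feature of the two cores separates the outcomes.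

The compounds shown leave open how an unsubstituted benzyl or a 4-aminophenyl on the same oxygen would behave on each core. For the compounds shown here, with only one pair on each core, they also leave open whether the gap between the cores would hold for any other group.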